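A few compounds are considered here, and "the series" means these few. Any claim that something is new, unique, unknown or untested is made for them only; others in the source may bear on it.

Working notes on a small series built on one shared core. Compound 1 `COc1ccc(-c2nc(CSc3cccc(Br)c3)nc3ccsc23)cn1` is the reference point. In an ADME assay on cells (Homo sapiens) for cytotoxicity, read by resazurin assay, with a stated time of 5 days (on this read-out higher numbers stand for lower toxicity in this test and lower numbers for higher toxicity in this test), compound 1 gives > 50000 nM, which is a limit of the assay rather than a number. Compound 2 `O=S(=O)(Cc1nc(-c2cccs2)c2sccc2n1)c1cccc(Cl)c1` belongs to the same series. In this assay compound 2 gives > 50000 nM, again a limit and not a number. Going by the values given here, compound 1 therefore stands at a limit only, and the one further value shown is a limit as well (the limit of > 50000 nM in this assay, at which 2 of the 2 values shown sit), so nothing orders the two against each other. Compound 3 `COc1ccc(-c2nc(CCc3cccc(Cl)c3)nc3ccsc23)cn1` is not yet measured. It differs from compound 1 by 3-chlorobenzyl in place of (3-bromophenyl)sulfanyl on a saturated chain carbon bound to an aromatic carbon. Among the compounds with values here, no step between measured compounds is in hand. A step that the limit leaves unreadable from compound 1 to compound 3 is expected, that is, none beyond the scatter. Compound 3 is estimated at 60000 nM, with a range from 30000 nM to 150000 nM, and is expected most likely to be reported as a limit once more.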

Compound 3, half-maximal cytotoxic concentration: > 50000 nM
Compound 3: no number, only a limit; the forecaster's own chance of this, stated with the estimate: 80%; the middle value lies beyond the limit too.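

Compound 1 and compound 3 both stand at a limit, so no step between them can be read in this assay: the limit of > 50000 nM in this assay, at which 3 of the 3 values shown sit.

The compounds shown leave open what actual value any of them has in this assay, and which changes to the shared core would give a readable number.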